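The compounds below may be only part of what the source reports. "The series", "measured", "known", "first", "only" and "open" are said of these compounds alone.

Working notes on the series.

Going by the values given here, compound 2 `CC(C)(CN)CCN(C[C@H]1Cc2ccccc2CN1)[C@H]1CCCc2cccnc21` is the weaker of the two measured members: in a functional assay on cells for antagonist activity at C-X-C chemokine receptor type 4 (Homo sapiens), read by fluorescence and calcium flux, with stated times of 25 min and 90 s (on this read-out higher numbers stand for weaker inhibition and lower numbers for stronger inhibition), compound 2 gives 69 nM, the higher of the two numbers, while compound 1 `c1ccc(CNCCCCN(C[C@H]2Cc3ccccc3CN2)[C@H]2CCCc3cccnc32)cc1` gives 20.1 nM in the same assay. Among the compounds with values here, the one step measured so far, a 3.4-fold higher number from compound 1 to compound 2 (0.54 log units; beyond the scatter), replaced the 2-(benzylamino)ethyl chain with the 1-(aminomethyl)-1-methylethyl group and moved the number up.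

Compound 3 `CC(C)(CCN(C[C@H]1Cc2ccccc2CN1)[C@H]1CCCc2cccnc21)CNCC1CCOCC1` keeps the chain of compound 2 and differs only in the change ((oxan-4-yl)methyl in place of hydrogen on an amine nitrogen), so the amine nitrogen that is unsubstituted in compound 2 now carries a ring-bearing methyl group, which brings the end of the chain back closer to the substituted amine present in compound 1. That single measured step bears on the expectation, but only loosely, since it changed the whole chain rather than the nitrogen alone. On that basis a modest move toward the lower number of compound 1 is expected for compound 3, as the step of a 2.0-fold lower number from compound 2 to compound 3 (0.29 log units; within the scatter), with the possibility that the change stays within the scatter. Compound 3 is estimated at 35 nM in this assay, in the range 12 nM to 100 nM.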

Compound 3, half-maximal inhibitory concentration: 43.8 nM
Estimate against measurement, compound 3: 1.3-fold (0.10 log units) below, and the stated range covers the measured number.
By their numbers in this assay, from the lowest: compound 1; then compounds 3 and 2 (each within the scatter of the next).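

Working notes, continued. In this assay, (oxan-4-yl)methyl in place of hydrogen on the amine nitrogen gives a 1.6-fold lower number from compound 2 to compound 3 (0.20 log units; within the scatter) and so stays within the scatter: this nitrogen of the chain of compound 2 can carry a group with a six-membered non-aromatic ring with no change that can be read in this assay. The comparison with the benzylamino chain shows a 2.2-fold higher number from compound 1 to compound 3 (0.34 log units; beyond the scatter) and lies beyond the scatter, so substitution on this nitrogen has not removed the modest gap to compound 1, although that step exchanges a whole group and cannot be assigned to the ring or to the methyl branching alone. Nothing measured alongside these numbers speaks to the result.

The compounds shown leave open whether a benzyl group on this same amine nitrogen, in the chain of compound 2, would reach the number of compound 1, which would separate the aromatic ring from the branched chain. Also open, as far as these compounds go, is how a cyclohexylmethyl or a 4-piperidinylmethyl group would read at this nitrogen.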